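The source may report more compounds than this note shows. Statements on the series, on what has been measured and on what is new or still open speak of the compounds shown alone.

Compound 1 `O=C(N/N=C/c1ccc(Cl)c(Cl)c1)Nc1ccc(Oc2ccnc3[nH]ccc23)c(F)c1`: 3700 nM
Compound 2 `O=C(N/N=C/c1ccc(F)cc1Cl)Nc1ccc(Oc2ccnc3[nH]ccc23)c(F)c1`: 1110 nM
Compound 3 `COc1ccc(/C=N/NC(=O)Nc2ccc(Oc3ccnc4[nH]ccc34)c(F)c2)cc1`: not yet measured

Among the compounds with values here, in a functional assay on HepG2 cells (Homo sapiens) for antiproliferative activity, read by MTT assay, with a stated time of 72 h (a lower number here means a stronger inhibitor, a higher number a weaker inhibitor), compound 2 gives 1110 nM, the lower of the two numbers so far. The next change is 4-methoxyphenyl in place of 2-chloro-4-fluorophenyl on a carbon with a double bond to nitrogen.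

Within the data shown here, one measured step bears on this place: a 3.3-fold lower number from compound 1 to compound 2 (0.52 log units; beyond the scatter). Among the measured compounds shown here, it is modest, and it is the only guide, since no measured compound carries 4-methoxyphenyl. Any direction is therefore tentative. Moving away from the group of compound 2 is expected to give a modest rise in this assay, of about the same size as that measured step. The expected change is a 2.3-fold higher number from compound 2 to compound 3 (0.35 log units; beyond the scatter). For compound 3 the estimated value is 2500 nM, with an expected range of 800 nM to 8000 nM.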

Compound 3, half-maximal inhibitory concentration: 1770 nM
Compound 3: middle estimate off by 1.4-fold (0.15 log units), on the high side; low and high end bracket the measured number.
By their numbers in this assay, from the lowest: compounds 2 and 3 (each within the scatter of the next); then compound 1.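

In this assay, a phenyl ring without halogen is accepted on the carbon with a double bond to nitrogen: 4-methoxyphenyl in place of 2-chloro-4-fluorophenyl gives a 1.6-fold higher number from compound 2 to compound 3 (0.20 log units; within the scatter), so halogen on this ring is not required among these compounds. Within the data shown here, replacing 3,4-dichlorophenyl with 4-methoxyphenyl gives a 2.1-fold lower number from compound 1 to compound 3 (0.32 log units; beyond the scatter), which leaves compound 1 as the one compound set apart from both others, while compounds 2 and 3 cannot be separated. Nothing available explains these differences.

Open, going by these compounds, is whether this place accepts a ring bearing an amine or a carboxylic acid, or a longer chain such as ethoxy in place of the methoxy group. Also open, on these data alone, is whether the chlorine at the 3-position or the one at the 4-position of 3,4-dichlorophenyl sets the number of compound 1.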